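Working notes: from compound 1 to compound 3

The compounds below may be only part of what the source reports. "The series", "measured", "known", "first", "only" and "open" are said of these compounds alone.

- compound 1 `FC(F)(F)c1cccc(-c2nc3cnc(Nc4ccccn4)cc3[nH]2)c1`: 45%
- compound 2 `COc1ccnc(Nc2cc3[nH]c(-c4cccc(C(F)(F)F)c4)nc3cn2)c1`: 71%

In an ADME assay on microsomes from liver (Rattus norvegicus) for metabolic stability, read by LC-MS, with a stated time of 30 min, tested at 0.1 uM (a higher number here means that more of the compound is left, a lower number that less of the compound is left), compound 1 stands lowest of the two measured compounds at 45%. Compound 3 `FC(F)(F)c1cccc(-c2nc3cnc(Nc4cnccn4)cc3[nH]2)c1` is still unmeasured and differs from it in one place: pyrazin-2-yl in place of pyridin-2-yl on a nitrogen on an aromatic ring. In words, pyrazin-2-yl stands in place of pyridin-2-yl on a nitrogen on an aromatic ring. Going by the values given here, the only measured step, a number 26 percentage points higher from compound 1 to compound 2 (beyond the scatter), is methoxy in place of hydrogen on an aromatic carbon. Among the compounds with values here, it is a different change and bears only loosely, and no measured step covers this swap. A small rise in this assay is tentatively expected, smaller than that step. The expected step is a number 9 percentage points higher from compound 1 to compound 3 (within the scatter). For compound 3 the estimated value is 54%, with an expected range of 33% to 76%.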

Compound 3, percent of the compound remaining: 20%
Compound 3: the middle estimate sits 34 percentage points above what was measured; measured number below the stated range.
By their numbers in this assay, from the lowest: compound 3; then compound 1; then compound 2.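

In this assay, the ring on this nitrogen can move the number down as well as up: pyrazin-2-yl in place of pyridin-2-yl gives a number 25 percentage points lower from compound 1 to compound 3 (beyond the scatter) and so costs stability, the opposite direction to the methoxy change. Against the methoxy-bearing ring, pyrazin-2-yl gives a number 51 percentage points lower from compound 2 to compound 3 (beyond the scatter), so this one place spans the full range of the three compounds. No measured data bear on why the added ring nitrogen goes with less compound remaining.

Open, from the compounds shown here alone, is whether methoxy on the pyrazin-2-yl ring would restore the number, and how a pyrimidin-2-yl group would compare.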